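From compound 3 to compound 4: an aryl swap

The compounds below may be only part of what the source reports. "The series", "measured", "known", "first", "only" and "open" are said of these compounds alone.

Values in a functional assay on ileum (Cavia porcellus) for inhibition; on this read-out lower numbers stand for stronger inhibition and higher numbers for weaker inhibition:
compound 1 `COC(=O)C1=C(C)NC(C)=C(C(=O)OC)C1c1c(-c2cccnc2)nc2sc(C)cn12`: 16000 nM
compound 2 `COC(=O)C1=C(C)NC(C)=C(C(=O)OC)C1c1c(-c2ccccn2)nc2sccn12`: 2570 nM
compound 3 `COC(=O)C1=C(C)NC(C)=C(C(=O)OC)C1c1c(-c2ccsc2)nc2sc(C)cn12`: 3520 nM
compound 4 `COC(=O)C1=C(C)NC(C)=C(C(=O)OC)C1c1c(-c2ccccn2)nc2sc(C)cn12`: not yet measured

Compound 3 lies within the scatter of compound 2 and clearly under compound 1. The change now in question is pyridin-2-yl in place of thiophen-3-yl on an aromatic carbon. Among the compounds with values here, the only measured step at this place is a 4.5-fold lower number from compound 1 to compound 3 (0.66 log units; beyond the scatter), which is modest and involves a different pyridine. Compound 2, which also carries pyridin-2-yl on a slightly different core, gives 2570 nM. Together these point to little movement in this assay, with a slight rise at most. The expected change is a 1.3-fold higher number from compound 3 to compound 4 (0.11 log units; within the scatter). For compound 4 the estimate is 4500 nM, with an expected range of 1500 nM to 13000 nM.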

Compound 4, half-maximal inhibitory concentration: 2810 nM
Estimate against measurement, compound 4: 1.6-fold (0.20 log units) above, within the range that was stated.
By their numbers in this assay, from the lowest: compounds 2, 4 and 3 (each within the scatter of the next); then compound 1.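

In this assay, pyridin-2-yl in place of pyridin-3-yl gives a 5.7-fold lower number from compound 1 to compound 4 (0.76 log units; beyond the scatter) and so separates the two pyridines at this aromatic carbon. Pyridin-2-yl in place of thiophen-3-yl gives a 1.3-fold lower number from compound 3 to compound 4 (0.10 log units; within the scatter) and leaves these two groups unresolved, so among the three groups compared here only the pyridin-3-yl of compound 1 stands apart. Methyl in place of hydrogen on an aromatic carbon gives a 1.1-fold higher number from compound 2 to compound 4 (0.04 log units; within the scatter) and is likewise unresolved on the pyridin-2-yl background. No evidence on the origin of these steps is available. As far as these compounds go, whether a phenyl ring at this position, or an amine on the pyridin-2-yl ring, would match these numbers remains open.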